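The compounds below may be only part of what the source reports. "The series", "measured", "known", "first", "only" and "open" are said of these compounds alone.

Compound 1 `Cc1cnc(C(=O)Nc2ccc(Br)c3cccnc23)cn1` gives 6800 nM in a functional assay on PANC-1 cells (Homo sapiens) for inhibition, read by MTT assay, with a stated time of 72 h; a lower number here means a stronger inhibitor, a higher number a weaker inhibitor.
Compound 2 `Cc1cnc(C(=O)Nc2cc(F)cc3cccnc23)cn1` gives 2100 nM in this assay.
Compound 3 `O=C(Nc1ccc(Br)c2cccnc12)c1cnccn1` gives 7000 nM in this assay.

Compound 1 and compound 3 share one core and differ in a single spot: hydrogen in place of methyl on an aromatic carbon. The measured step of a 1.0-fold higher number from compound 1 to compound 3 (0.01 log units; within the scatter) shows that this change left the number essentially where it was. Compound 2 is built on a different core; how the two cores differ is not broken down here. Compound 2 has the lowest number of the three, and its gaps to compound 1 and to compound 3 are both beyond the usual scatter.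

Compound 4 `O=C(Nc1cc(F)cc2cccnc12)c1cnccn1` has not yet been measured. Among the compounds with values here, it differs from compound 2 by hydrogen in place of methyl on an aromatic carbon, which is the same change as the one from compound 1 to compound 3, made at the same kind of place. Because a 1.0-fold higher number from compound 1 to compound 3 (0.01 log units; within the scatter) stayed within the scatter, the expected step of a 1.0-fold higher number from compound 2 to compound 4 (0.02 log units; within the scatter) is also small. Compound 4 is therefore estimated at 2200 nM in this assay, expected to fall between 1000 nM and 5000 nM. This rests on a single earlier instance of the change, so the range is kept wide.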

Compound 4, half-maximal inhibitory concentration: 670 nM
Compound 4: the middle estimate sits 3.3-fold (0.52 log units) above what was measured; measured number outside the range, below it.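

In this assay, trimming 5-methylpyrazin-2-yl to pyrazin-2-yl gives a 3.1-fold lower number from compound 2 to compound 4 (0.50 log units; beyond the scatter), so the same small change does not produce the same step on the two cores: the same change on two cores in this assay, a 1.0-fold higher number (0.01 log units; within the scatter) from compound 1 to compound 3 and a 3.1-fold lower number (0.50 log units; beyond the scatter) from compound 2 to compound 4, 3.2-fold (0.51 log units) apart, beyond the scatter of two such steps

A result for this change on one core therefore cannot simply be copied onto another core in this series, even when the change is made at the same kind of place. What these numbers do not show is why the two cores respond differently, and with just one pair on each core they cannot say which response would be the more usual on a further core.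

The compounds shown carry only methyl or hydrogen at this place, so it remains open how a longer chain such as ethyl, or an amine, would behave there on either core. On these data alone, it is also open whether the difference between the two cores would persist in any test other than this assay.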